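This account rests on a few compounds, and the source may have more. Where it says the series, first, only, none or still open, it means among the compounds named here.

Measured compounds

Compound 1, `N/C(=N\NC(=S)N1CCCCCC1)c1ccccn1`: 89%
Compound 2, `Cc1ccnc(/C(N)=N/NC(=S)N2CCN(c3ccccn3)CC2)c1`: 81%
Compound 3, `Cc1cccc(/C(N)=N/NC(=S)N2CCCCCC2)n1`: 80.9%

Three thiosemicarbazide-type compounds have been tested in a functional assay on A-375 cells (Homo sapiens) for cytotoxicity, read by MTT assay, with a stated time of 72 h, tested at 100 uM; on this read-out lower numbers stand for less inhibition of growth and higher numbers for more inhibition of growth at the one concentration tested. Compound 1 gives 89%, compound 2 gives 81%, and compound 3 gives 80.9%. All three values lie within the usual scatter of one another, so no order among them can be read.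

Compound 3 and compound 1 differ in one place, (hydrogen in place of methyl on an aromatic carbon), and the step in this assay is a number 8.1 percentage points higher from compound 3 to compound 1 (within the scatter). Compound 2 and compound 3 have different cores; the difference between the two cores is not broken down here.

A fourth compound, compound 4, `N/C(=N\NC(=S)N1CCN(c2ccccn2)CC1)c1ccccn1`, has not yet been measured in this assay. It differs from compound 2 by hydrogen in place of methyl on an aromatic carbon. Among the measured compounds shown here, this is the same kind of change as the one from compound 3 to compound 1, but not the same: in compound 3 the methyl sits next to the ring nitrogen, whereas in compound 2 it sits opposite the ring nitrogen, both meta to a large group.

For the measured compounds named here, because the one measured step of this kind, a number 8.1 percentage points higher from compound 3 to compound 1 (within the scatter), lay within the scatter, the step from compound 2 to compound 4 is expected to be small as well, about a number 4 percentage points higher from compound 2 to compound 4 (within the scatter), with the upper range limited by the fact that growth inhibition cannot far exceed complete inhibition. Compound 4 is therefore estimated to give 85%, with a likely range from 70% to 96%.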

Compound 4, percent growth inhibition at one concentration: 86.8%
Estimate against measurement, compound 4: 1.8 percentage points below, and the stated range covers the measured number.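

In this assay, the change from 4-methylpyridin-2-yl to pyridin-2-yl gives a number 5.8 percentage points higher from compound 2 to compound 4 (within the scatter). Set beside the earlier step, the same exchange of methyl for hydrogen on an aromatic carbon reads alike on the two cores, though the methyl does not sit in the same place on the ring in both pairs: the same change on two cores in this assay, a number 8.1 percentage points higher (within the scatter) from compound 3 to compound 1 and a number 5.8 percentage points higher (within the scatter) from compound 2 to compound 4, 2.3 percentage points apart, within the scatter of two such steps This shows only that no dependence on the core can be seen across these two pairs; it does not show that the change has any effect of its own, since each step taken alone lies within the scatter, and two pairs tested at a single concentration cannot establish a rule for the series.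

The compounds shown leave open what other groups at this place on the pyridine ring would do, such as an ethyl group, a longer chain, a methoxy group, a chlorine atom or an amine, and whether a methyl group at the remaining ring carbons would read the same. They also leave open whether the exchange of methyl for hydrogen would read alike on a third core, or at lower concentrations where growth inhibition is less complete.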